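Adding a chloro group to a fluorinated inhibitor scaffold

The source may hold more compounds than are shown below. What is called first, only, known or untested is meant among the compounds shown, and "the series" means these compounds.

Measured so far:
- compound 1, `O/N=C(/Nc1ccc(Cl)cc1)c1ccc2occc2c1`: > 30000 nM in an assay on tissue (HeLa cells) for inhibition of Indoleamine 2,3-dioxygenase 1 (Homo sapiens), read by spectrophotometry; a lower number here means a stronger inhibitor, a higher number a weaker inhibitor
- compound 2, `O/N=C(/Nc1cccc(F)c1)c1ccc2occc2c1`: 20000 nM
- compound 3, `O/N=C(/Nc1cccc(Br)c1)c1ccc2occc2c1`: 1100 nM.

For compound 1 the value is a limit of this assay, not a number. Among the two numbers, compound 2 stands highest, and compound 3 is the nearest to it. Within the data shown here, the one step measured so far is an 18-fold lower number from compound 2 to compound 3 (1.26 log units; beyond the scatter), showing that swapping the halogen on the ring can shift this assay a great deal.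

Compound 4, `O/N=C(/Nc1ccc(Cl)c(F)c1)c1ccc2occc2c1`, keeps the fluoro group of compound 2 and adds another halogen: chloro in place of hydrogen on an aromatic carbon. Among the measured compounds shown here, no measured step makes exactly this change. For the measured compounds named here, the only guidance is that compound 1, which carries chloro alone at that place, reaches only the limit (the limit of > 30000 nM in this assay, at which 1 of the 3 values shown sits), so the added chloro is not expected to help much. For compound 4 the expected step is therefore no change at the digits printed from compound 2 to compound 4 (within the scatter), small or none beyond the scatter. The estimate for compound 4 is 20000 nM, between 4000 nM and 100000 nM.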

Compound 4, half-maximal inhibitory concentration: 10300 nM
Compound 4: middle estimate off by 1.9-fold (0.29 log units), on the high side; low and high end bracket the measured number.
By their numbers in this assay, from the lowest: compound 3; then compounds 4 and 2 (each within the scatter of the next). At a limit, above all of these: compound 1.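

In this assay, chloro in place of hydrogen, para to a large group and ortho to a fluoro group, gives a 1.9-fold lower number from compound 2 to compound 4 (0.29 log units; within the scatter), so on this fluorinated compound the added chloro shifts the number by no more than the usual scatter. Seen from the other side, fluoro in place of hydrogen gives an at least 2.9-fold lower number from compound 1 to compound 4 (0.46 log units; beyond the scatter), which shows that a compound carrying chloro at this place can still return a measurable number once fluoro is also present. The value of compound 1 is a limit, so this second step gives only a minimum size: the limit of > 30000 nM in this assay, at which 1 of the 4 values shown sits.

On these data alone, what an amine or a carboxylic acid would do at the place now held by chloro remains open. Also open, as far as these compounds go, is whether a bromo group at this place would bring a step as large as an 18-fold lower number from compound 2 to compound 3 (1.26 log units; beyond the scatter) seen with the other bromo-for-fluoro change.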